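The source may hold more compounds than are shown below. What is called first, only, known or untested is meant among the compounds shown, and "the series" means these compounds.

Measured in a functional assay on cells for agonist activity at C-X-C chemokine receptor type 4 (Homo sapiens), read by fluorescence and calcium flux, with a stated time of 90 s; on this read-out lower numbers stand for an effect already at smaller amounts and higher numbers for an effect only at larger amounts of compound:
Compound 1 `c1ccc2c(c1)CN[C@@H](CN(CCCCNC1CCNCC1)[C@H]1CCCc3cccnc31)C2` gives > 30000 nM, which is a limit of the assay.
Compound 2 `c1ccc2c(c1)CN[C@@H](CN(CCCCNC1CCSCC1)[C@H]1CCCc3cccnc31)C2` gives > 30000 nM, a limit.
Compound 3 `FC1(F)CCC(NC/C=C/CN(C[C@H]2Cc3ccccc3CN2)[C@H]2CCCc3cccnc32)CC1` gives > 30000 nM, a limit.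

Compound 3 therefore stands only at a limit, and so do both other compounds, since all values sit at the limit of > 30000 nM in this assay, at which 3 of the 3 values shown sit. Within the data shown here, the single measured step, thian-4-yl in place of piperidin-4-yl on an amine nitrogen, is a step that the two limits leave unreadable from compound 1 to compound 2, so its size cannot be read. Among the measured compounds shown here, the change to compound 4 `C(=C/CN(C[C@H]1Cc2ccccc2CN1)[C@H]1CCCc2cccnc21)\CNCc1cccnc1` is (pyridin-3-yl)methyl in place of 4,4-difluorocyclohexyl on an amine nitrogen, a different amine substituent, and no measured step bears readably on it. With nothing readable behind it, the expected step is a step that the limit leaves unreadable from compound 3 to compound 4, most likely again only a limit. Compound 4 is estimated at 40000 nM, with a range of 10000 nM to 150000 nM.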

Compound 4, half-maximal effective concentration: > 30000 nM
Compound 4: only a limit was reported; the forecaster's own chance of this, stated with the estimate: 75%; the middle value lies beyond the limit too.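

Compound 4 gives > 30000 nM as a limit of the assay, so its steps from compound 1, compound 2 and compound 3 cannot be read. Whether these amine substituents differ at all in this assay remains open among the compounds shown.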